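Extending the ethyl chain of compound 2 to butyl

The source may hold more compounds than are shown below. What is called first, only, known or untested is meant among the compounds shown, and "the series" means these compounds.

Compound 2, `CCCc1cc(N)c2cc(NC(=O)/C=C/c3ccc(CC)cc3)ccc2n1`, is studied in a functional assay on HEK293 cells for activation of melanin-concentrating hormone receptor 1 (Homo sapiens), read by inositol phosphate accumulation; a lower number here means that less compound is needed, a higher number that more compound is needed for the effect. Compound 2 gives 160 nM, the highest of the three numbers measured. Compound 3, `CCCc1cc(N)c2cc(NC(=O)c3ccc(-c4ccc(Cl)cc4)cc3)ccc2n1`, gives 75 nM, and compound 1, `Nc1cc(C2CCCC2)nc2ccc(NC(=O)/C=C/c3ccc(C(F)(F)F)cc3)cc12`, gives 68 nM; both of these lie beyond the scatter below the value of compound 2. Compound 4, `CCCCc1ccc(/C=C/C(=O)Nc2ccc3nc(CCC)cc(N)c3c2)cc1`, is not yet measured. It differs from compound 2 by ethyl in place of hydrogen on a saturated chain carbon, two bonds along the chain from an aromatic carbon, so that ethyl becomes butyl. Going by the values given here, no measured pair shows this particular change, so its effect can only be guessed from the fact that compound 1 and compound 3, which carry other groups in that region, give lower numbers than compound 2. A small step toward a lower number is expected from compound 2 to compound 4, a 1.6-fold lower number from compound 2 to compound 4 (0.20 log units; within the scatter), close to the edge of the scatter. Compound 4 is therefore estimated at 100 nM, with a range from 40 nM to 300 nM.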

Compound 4, half-maximal effective concentration: 740 nM
The estimate for compound 4 lay 7.4-fold (0.87 log units) below the measured number, and the stated range ends below it.
By their numbers in this assay, from the lowest: compounds 1 and 3 (each within the scatter of the next); then compound 2; then compound 4.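

Replacing hydrogen with ethyl on the saturated chain carbon, which turns ethyl into butyl, gives a 4.6-fold higher number from compound 2 to compound 4 (0.67 log units; beyond the scatter) in this assay. This is the only step shown that can be read at a single place, and it shows that the number at this position responds to chain length, with the longer chain here needing more compound for the effect. No measurement shown accounts for this rise.

Going by these compounds alone, with only this one step, it remains open whether the number climbs gradually as the chain grows or changes abruptly at butyl. Going by these compounds, it is also open how a hexyl chain, a methoxy group, an amine or a carboxylic acid would read at this position on the shared core.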